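The source may report more compounds than this note shows. Statements on the series, on what has been measured and on what is new or still open speak of the compounds shown alone.

Measured in a functional assay on A549 cells (Homo sapiens) for antiproliferative activity, read by MTT assay, with a stated time of 72 h; a higher number here means a weaker inhibitor, a lower number a stronger inhibitor:
compound 1 `CNC(=O)c1cc(Oc2ccc(NC(=O)c3cc4cccnc4n(-c4ccccc4)c3=O)cc2)ccn1` gives 200 nM
compound 2 `CNC(=O)c1cc(Oc2ccc(NC(=O)c3cc4cccnc4n(-c4ccc(Cl)cc4)c3=O)cc2)ccn1` gives 370 nM
compound 3 `CNC(=O)c1cc(Oc2ccc(NC(=O)c3cc4cccnc4n(-c4ccc(OC)cc4)c3=O)cc2)ccn1` gives 3110 nM

Compound 3 stands highest of the three numbers in this assay: a 16-fold higher number from compound 1 to compound 3 (1.19 log units; beyond the scatter), and an 8.4-fold higher number from compound 2 to compound 3 (0.92 log units; beyond the scatter). Compound 4 `CNC(=O)c1cc(Oc2ccc(NC(=O)c3cc4cccnc4n(-c4ccc(Br)cc4F)c3=O)cc2)ccn1` differs from compound 3 by 4-bromo-2-fluorophenyl in place of 4-methoxyphenyl on an aromatic nitrogen. Within the data shown here, two measured steps bear on this change. The reverse of the relevant direction is seen in an 8.4-fold higher number from compound 2 to compound 3 (0.92 log units; beyond the scatter), where a methoxy entering for a chloro raised the number; and a 1.9-fold higher number from compound 1 to compound 2 (0.27 log units; within the scatter) shows chloro and hydrogen within the scatter. Because an 8.4-fold higher number from compound 2 to compound 3 (0.92 log units; beyond the scatter) was modest and beyond the scatter, the bromo-fluoro ring is expected to bring the number back down, with a step of a 6.2-fold lower number from compound 3 to compound 4 (0.79 log units; beyond the scatter). Compound 4 is therefore estimated at 500 nM, in the range 150 nM to 1800 nM.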

Compound 4, half-maximal inhibitory concentration: 1420 nM
The estimate for compound 4 lay 2.8-fold (0.45 log units) below the measured number, within the range that was stated.
By their numbers in this assay, from the lowest: compounds 1 and 2 (each within the scatter of the next); then compound 4; then compound 3.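

In this assay, 4-bromo-2-fluorophenyl on the aromatic nitrogen gives a lower number than 4-methoxyphenyl (a 2.2-fold lower number from compound 3 to compound 4 (0.34 log units; beyond the scatter)), yet a higher one than 4-chlorophenyl (a 3.8-fold higher number from compound 2 to compound 4 (0.58 log units; beyond the scatter)) or phenyl (a 7.1-fold higher number from compound 1 to compound 4 (0.85 log units; beyond the scatter)). Halogen-bearing rings therefore do not all read alike at this position: compound 2 stays within the scatter of compound 1, while compound 4 does not. No measurement given here accounts for this difference. The compounds shown do not separate the bromo from the fluoro contribution. As far as these compounds go, how an amine or a carboxylic acid on this ring would read also remains open.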